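From 2-chlorophenyl to 3-hydroxyphenyl

The source may report more compounds than this note shows. Statements on the series, on what has been measured and on what is new or still open speak of the compounds shown alone.

Measured in a functional assay (muscle tissue) with Cavia porcellus as the target; on this read-out lower numbers stand for an effect already at smaller amounts and higher numbers for an effect only at larger amounts of compound:
- compound 1 `COC(=O)C1=C(C)N=C(C)/C(=C(\O)OC)C1c1ccc(Cl)cc1` gives 8130 nM
- compound 2 `COC(=O)C1=C(C)N=C(C)/C(=C(\O)OC)C1c1ccccc1Cl` gives 2.19 nM

Compound 2 holds the lower of the two numbers, and compound 1 stands far above it. Compound 3 `COC(=O)C1=C(C)N=C(C)/C(=C(\O)OC)C1c1cccc(O)c1` keeps the shared core but carries 3-hydroxyphenyl in place of 2-chlorophenyl on a saturated ring carbon in the structure. Within the data shown here, one measured step bears on this change: a 3700-fold lower number from compound 1 to compound 2 (3.57 log units; beyond the scatter). That step is large, and it came from exchanging only 4-chlorophenyl for 2-chlorophenyl, so the group at this place can matter greatly. Compound 3 carries neither chlorophenyl group, which means the step cannot simply be transferred. Compound 2 sits at 2.19 nM at the low end, so a sizeable move to a higher number is expected in this assay, probably stopping short of the number for compound 1. The estimate is a 91-fold higher number from compound 2 to compound 3 (1.96 log units; beyond the scatter). For compound 3 the expected value is 200 nM with an estimated range from 20 nM to 2000 nM.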

Compound 3, half-maximal effective concentration: 1000 nM
Estimate against measurement, compound 3: 5.0-fold (0.70 log units) below, within the range that was stated.
By their numbers in this assay, from the lowest: compound 2; then compound 3; then compound 1.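

In this assay, exchanging 2-chlorophenyl for 3-hydroxyphenyl gives a 460-fold higher number from compound 2 to compound 3 (2.66 log units; beyond the scatter), even though the two groups have the same number of heavy atoms and each holds one six-membered aromatic ring of carbon only. Exchanging 4-chlorophenyl for the same 3-hydroxyphenyl gives the smaller 8.1-fold lower number from compound 1 to compound 3 (0.91 log units; beyond the scatter), so among these three groups, 2-chlorophenyl alone reaches the low end, and 3-hydroxyphenyl stands between the two chlorophenyl groups. Nothing measured here gives a reason for these differences.

As far as these compounds go, in these compounds, chlorine and hydroxyl never sit at the same ring position, so it stays open how much of the change comes from the atom and how much from where it sits. A 3-chlorophenyl or 2-hydroxyphenyl group would separate the two, and a 2-aminophenyl group would test another atom at the position held by chlorine in compound 2.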